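A few compounds are considered here, and "the series" means these few. Any claim that something is new, unique, unknown or untested is made for them only; others in the source may bear on it.

Compound 1 `COc1cc(CS(=O)(=O)c2nc3ccccc3[nH]2)ccc1OCc1ncc(C)c(OC)c1C` gives in a functional assay on cells (Erythrocyte, Homo sapiens) (a lower number here means a stronger inhibitor, a higher number a weaker inhibitor), a value of 1820 nM. Compound 2 `COc1cc(CS(=O)(=O)c2nc3cc(OC(F)F)ccc3[nH]2)ccc1OCc1ncc(C)c(OC)c1C` carries difluoromethoxy in place of hydrogen on an aromatic carbon; in this assay compound 2 gives 1420 nM, so that a 1.3-fold lower number from compound 1 to compound 2 (0.11 log units; within the scatter). Compound 3 `COc1cc(CS(=O)(=O)c2nc3ccccc3[nH]2)ccc1OCc1nccc(OC)c1OC` differs from compound 1 in its core by 3,4-dimethoxypyridin-2-yl in place of 4-methoxy-3,5-dimethylpyridin-2-yl on a saturated chain carbon bound to an oxygen on an aromatic ring, and in this assay compound 3 gives 212 nM, a step described as an 8.6-fold lower number from compound 1 to compound 3 (0.93 log units; beyond the scatter). Compound 4 `COc1cc(CS(=O)(=O)c2nc3cc(OC(F)F)ccc3[nH]2)ccc1OCc1nccc(OC)c1OC` has not been measured; it is related to compound 3 by difluoromethoxy in place of hydrogen on an aromatic carbon, the same change, at the same place, as that from compound 1 to compound 2. Since that earlier step stayed within the scatter, the step from compound 3 to compound 4 is expected to be small as well, about a 1.2-fold lower number from compound 3 to compound 4 (0.08 log units; within the scatter). Compound 4 is therefore estimated at 175 nM, between 80 nM and 400 nM.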

Compound 4, half-maximal inhibitory concentration: 186 nM
Compound 4: the middle estimate sits 1.1-fold (0.03 log units) below what was measured; the range from low to high includes it.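

In this assay, difluoromethoxy in place of hydrogen again gave a step within the scatter, with a 1.1-fold lower number from compound 3 to compound 4 (0.06 log units; within the scatter), and the two cores agree: the same change on two cores in this assay, a 1.3-fold lower number (0.11 log units; within the scatter) from compound 1 to compound 2 and a 1.1-fold lower number (0.06 log units; within the scatter) from compound 3 to compound 4, 1.1-fold (0.05 log units) apart, within the scatter of two such steps. The exchange of 4-methoxy-3,5-dimethylpyridin-2-yl for 3,4-dimethoxypyridin-2-yl also carried over, with a 7.6-fold lower number from compound 2 to compound 4 (0.88 log units; beyond the scatter), and its size held: the same change on two cores in this assay, an 8.6-fold lower number (0.93 log units; beyond the scatter) from compound 1 to compound 3 and a 7.6-fold lower number (0.88 log units; beyond the scatter) from compound 2 to compound 4, 1.1-fold (0.05 log units) apart, within the scatter of two such steps. Together these four compounds show each change behaving alike whether or not the other is present, but they do not show that this extends to other groups, other cores or other assays.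

Going by these compounds, it remains open which part of the pyridine exchange carries the step, the methyl groups lost or the methoxy gained. On these data alone, it is also open whether an amine or a carboxylic acid on that aromatic carbon would give as small a step as difluoromethoxy.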